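Removing a chlorine from a weak cytotoxic compound

The compounds below may be only part of what the source reports. "The series", "measured", "known", "first", "only" and "open" are said of these compounds alone.

A pair of compounds built on a shared core have been tested in a functional assay on MCF7 cells (Homo sapiens) for cytotoxicity, read by MTT assay, with a stated time of 48 h; on this read-out lower numbers stand for stronger inhibition and higher numbers for weaker inhibition. Compound 1 `COc1ccc(/C=C2\N=C(c3ccc(C)cc3)N(C(=O)c3nc4c(c(C)nn4-c4ccccc4)c(=O)[nH]3)NC2=O)cc1` gives 17.3 nM in this assay. Compound 2 `Cc1nn(-c2ccccc2)c2nc(C(=O)N3NC(=O)/C(=C/c4ccc(Cl)cc4)N=C3c3ccccc3)[nH]c(=O)c12` gives 4430 nM in this assay, the higher of the two numbers, and its gap to compound 1 lies well beyond the scatter. Among the compounds with values here, compound 1 and compound 2 differ in more than one place, so their two values show only that compound 2 is the weaker of the pair. The next compound, compound 3 `Cc1nn(-c2ccccc2)c2nc(C(=O)N3NC(=O)/C(=C/c4ccccc4)N=C3c3ccccc3)[nH]c(=O)c12`, has not yet been measured. It differs from compound 2 in a single way: hydrogen in place of chloro on an aromatic carbon, para to a large group. Within the data shown here, no measured pair shows this exact change on its own, so there is no step to lean on. For compound 3 the step of a 1.5-fold lower number from compound 2 to compound 3 (0.17 log units; within the scatter) is expected to be small, with the number in this assay perhaps a little lower but not clearly beyond the scatter. The estimate for compound 3 in this assay is 3000 nM, with a range from 800 nM to 12000 nM.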

Compound 3, half-maximal inhibitory concentration: 120 nM
Compound 3: middle estimate off by 25-fold (1.40 log units), on the high side; the whole stated range lies above it.
By their numbers in this assay, from the lowest: compound 1; then compound 3; then compound 2.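

In this assay, the chloro on an aromatic carbon, para to a large group, turns out to matter a great deal: the change from 4-chlorophenyl to phenyl gives a 37-fold lower number from compound 2 to compound 3 (1.57 log units; beyond the scatter). The earlier gap between compound 1 and compound 2 could not be tied to any single place, as those two differ in more than one. Here a single chlorine atom gives way to hydrogen and nothing else changes, so this position is shown to be one where the number responds strongly, though no measurement at hand explains why.

On these data alone, whether the chloro is unusual here, or any group at this position would raise the number in a similar way, stays open; a fluoro, a bromo or an amine on the same carbon would begin to separate those two readings. As far as these compounds go, it also remains unknown whether this step would keep its size with the other groups carried by compound 1, which differs from compound 3 in more than one place.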